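Pyrrolidinyl to piperidinyl step in the amide series

The compounds below may be only part of what the source reports. "The series", "measured", "known", "first", "only" and "open" are said of these compounds alone.

Measured so far in an assay on Sf9 cells for inhibition of Leucine-rich repeat serine/threonine-protein kinase 2 (Homo sapiens), read by TR-FRET, with stated times of 30 min and 2 h; a lower number here means a stronger inhibitor, a higher number a weaker inhibitor:
Compound 1 `O=C(Nc1ccnnc1)c1cc(N2CCCC2)ccc1OCc1ccccc1` gives 20 nM.
Compound 2 `O=C(Nc1ccnnc1)c1cc(N2CCC(O)CC2)ccc1OCc1ccccc1` gives 39.8 nM.
Compound 3 `O=C(Nc1cccnc1)c1cc(C(F)(F)F)ccc1OCc1ccccc1` gives 12.6 nM.

Compound 1 stands second highest of the three numbers in this assay; compound 3 is nearest, and its value and that of compound 1 lie within the scatter of each other, as do the values of compound 1 and compound 2.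

Compound 4 `O=C(Nc1ccnnc1)c1cc(N2CCCCC2)ccc1OCc1ccccc1` is not yet measured. Its difference from compound 1: piperidin-1-yl in place of pyrrolidin-1-yl on an aromatic carbon.

Among the measured compounds shown here, the one measured step that bears on this is a 2.0-fold higher number from compound 1 to compound 2 (0.30 log units; within the scatter). That step brings in a ring of the size that compound 4 carries, though with a hydroxyl on it, and stays within the scatter. Nothing here separates the ring-size part of that step from the hydroxyl part. Compound 3 carries no such ring, so it gives no further guide. The expectation for compound 4 in this assay is therefore a step no larger than the scatter, if anything towards a slightly higher number, as a 1.3-fold higher number from compound 1 to compound 4 (0.10 log units; within the scatter).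

Compound 4 is estimated at 25 nM in this assay, with a range from 10 nM to 63 nM.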

Compound 4, half-maximal inhibitory concentration: 25.1 nM
Compound 4: middle estimate off by 1.0-fold (0.00 log units), on the low side; low and high end bracket the measured number.
By their numbers in this assay, from the lowest: compounds 3, 1, 4 and 2 (each within the scatter of the next, the first and the last beyond it).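

In this assay, the change of ring size can now be read apart from the hydroxyl: a 1.3-fold higher number from compound 1 to compound 4 (0.10 log units; within the scatter) lies within the scatter, so at this position, para to a benzyloxy group, piperidin-1-yl and pyrrolidin-1-yl are not told apart. The hydroxy on the saturated ring is not resolved either, since a 1.6-fold lower number from compound 2 to compound 4 (0.20 log units; within the scatter) also lies within the scatter, which means that neither part of the earlier change from compound 1 to compound 2 stands out on its own. Nothing at hand gives a reason for either result.

Still open, on these data alone, is whether this position keeps the same range with groups of another kind, such as morpholin-4-yl, a piperazine carrying a free amine, an open-chain dimethylamino group, or a piperidine bearing a carboxylic acid. Compound 3 differs from these compounds in more than one place, in both its trifluoromethyl group and its amide part, so it does not show how trifluoromethyl would behave alongside the (pyridazin-4-yl)carbamoyl group.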